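A few compounds are considered here, and "the series" means these few. Any claim that something is new, unique, unknown or untested is made for them only; others in the source may bear on it.

Measured compounds in a functional assay on A549 cells (Homo sapiens) for cytotoxicity, read by sulforhodamine B assay, with a stated time of 72 h; on this read-out higher numbers stand for weaker inhibition and lower numbers for stronger inhibition:
- compound 1 `CCS(=O)(=O)Nc1cc(-c2ccc3ncnc(Nc4ccc(OC(F)(F)F)cc4)c3c2)cnc1OC`: 25400 nM
- compound 2 `CCS(=O)(=O)Nc1cc(-c2ccc3ncnc(Nc4ccc(OC)cc4)c3c2)cnc1OC`: 3580 nM

Compound 2 holds the lowest number of the two in this assay; its nearest neighbour is compound 1, the gap being a 7.1-fold lower number from compound 1 to compound 2 (0.85 log units; beyond the scatter). Among the compounds with values here, that single step, methyl in place of trifluoromethyl on an oxygen on an aromatic ring, is the only measured change on the aryl group attached to the amino nitrogen, and it is of modest size.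

Compound 3 `CCS(=O)(=O)Nc1cc(-c2ccc3ncnc(Nc4ccc(OC)c(OC)c4)c3c2)cnc1OC` differs from compound 2 by methoxy in place of hydrogen on an aromatic carbon. Within the data shown here, no measured pair shows a second methoxy entering this ring, so the step from compound 1 to compound 2 bears on it only loosely, as a sign that substitution on this aryl group moves the number by a modest amount. For compound 3 the expected step is a 1.2-fold lower number from compound 2 to compound 3 (0.08 log units; within the scatter), a change estimated to stay within the scatter. Compound 3 is therefore estimated at 3000 nM in this assay, with a range of 1000 nM to 10000 nM.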

Compound 3, half-maximal inhibitory concentration: 5820 nM
Estimate against measurement, compound 3: 1.9-fold (0.29 log units) below; the measured number falls inside the stated range.
By their numbers in this assay, from the lowest: compounds 2 and 3 (each within the scatter of the next); then compound 1.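

In this assay, methoxy in place of hydrogen on the aromatic carbon ortho to a methoxy group gives a 1.6-fold higher number from compound 2 to compound 3 (0.21 log units; within the scatter), so at this position the added methoxy brings no change that can be told from the scatter. The 3,4-dimethoxyphenyl group still gives a 4.4-fold lower number from compound 1 to compound 3 (0.64 log units; beyond the scatter), so the separation from the 4-(trifluoromethoxy)phenyl group first seen with 4-methoxyphenyl persists with the added methoxy. No measurement available here accounts for either step.

On these data alone, whether an amine, a carboxylic acid or a longer alkoxy chain on this same carbon would move the number beyond the scatter remains open. Also open, as far as these compounds go, is whether the flat result at this position would hold with a group other than methoxy, such as a dimethylamino group, in place of the existing methoxy.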